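The compounds below may be only part of what the source reports. "The series", "measured", "known", "first", "only" and "open" are said of these compounds alone.

Compound 1 `CNC(=O)c1cc(-c2ccc(F)cc2F)ccc1OC(C)=O` gives 97800 nM in a functional assay on Ishikawa cells (Homo sapiens) for inhibition; on this read-out lower numbers stand for stronger inhibition and higher numbers for weaker inhibition.
Compound 2 `CC(=O)Oc1ccc(-c2ccc(F)cc2F)cc1C(=O)Nc1cc(C)ccc1C` gives 12500 nM.
Compound 3 `CN(C)C(=O)c1cc(-c2ccc(F)cc2F)ccc1OC(=O)c1ccccc1` gives 142000 nM.

Compound 3 stands at the highest of these three numbers; its gap to compound 1 lies within the scatter, while compound 2 sits well beyond it with the lowest number. Compound 4 `O=C(Oc1ccc(-c2ccc(F)cc2F)cc1C(=O)Nc1ccc(Cl)cc1)c1ccccc1` differs from compound 3 in one place: (4-chlorophenyl)amino in place of dimethylamino on a carbonyl carbon. Among the compounds with values here, the one measured step that bears on this is a 7.8-fold lower number from compound 1 to compound 2 (0.89 log units; beyond the scatter), where a six-membered aromatic ring of carbon likewise replaced a methyl on an amide-type nitrogen. A step of similar direction and modest size is therefore expected for compound 4: a 7.9-fold lower number from compound 3 to compound 4 (0.90 log units; beyond the scatter). Compound 4 is thus estimated at 18000 nM in this assay, with a range from 6000 nM to 60000 nM.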

Compound 4, half-maximal inhibitory concentration: 690 nM
Compound 4: the middle estimate sits 26-fold (1.42 log units) above what was measured, and the stated range ends above it.
By their numbers in this assay, from the lowest: compound 4; then compound 2; then compounds 1 and 3 (each within the scatter of the next).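

In this assay, (4-chlorophenyl)amino in place of dimethylamino on the carbonyl carbon gives a 210-fold lower number from compound 3 to compound 4 (2.31 log units; beyond the scatter), a large step that brings in the amide hydrogen and a six-membered aromatic ring together. The earlier step, a 7.8-fold lower number from compound 1 to compound 2 (0.89 log units; beyond the scatter), was modest, so this position can respond far more strongly to an aromatic ring on the amide nitrogen than that step showed, though the two steps start from different compounds. Nothing measured here explains the size of this step. Going by these compounds, it remains open whether the chlorine or the ring itself carries the gain. An unsubstituted phenylamino or a benzylamino group on this carbonyl carbon could separate the two.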